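The source may hold more compounds than are shown below. What is called first, only, known or untested is meant among the compounds shown, and "the series" means these compounds.

Of the compounds shown here, three sharing one core have been tested in a functional assay on A549 cells (Homo sapiens) for antiproliferative activity, read by sulforhodamine B assay, with a stated time of 72 h; on this read-out higher numbers stand for weaker inhibition of growth and lower numbers for stronger inhibition of growth. Compound 1, `Cc1cc(=O)oc2cc(SC3CCOC3=O)ccc12`, gives in this assay only a limit, > 36100 nM, and no number. Compound 2, `Cc1cc(=O)oc2cc(SCc3cccc(C(F)(F)F)c3)ccc12`, likewise gives in this assay only a limit, > 28500 nM. Compound 3, `COc1cc(CSc2ccc3c(C)cc(=O)oc3c2)cc(OC)c1`, also gives in this assay only a limit, > 29200 nM. Compound 2 therefore stands nowhere in particular among the numbers shown: all three results are limits, as the limit of > 28500 nM in this assay, at which 1 of the 3 values shown sits, the limit of > 29200 nM in this assay, at which 1 of the 3 values shown sits, and the limit of > 36100 nM in this assay, at which 1 of the 3 values shown sits, record, and none of them can be ordered against another.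

Compound 4, `Cc1cc(=O)oc2cc(SCc3cccc(OC(F)(F)F)c3)ccc12`, differs from compound 2 in one place: trifluoromethoxy in place of trifluoromethyl on an aromatic carbon. Within the data shown here, no step between two measured compounds is available to show what this kind of change does in this assay. With compound 2 at a limit, no movement beyond the usual scatter is expected in either direction, and the most likely outcome for compound 4 is again a limit rather than a number. The expected value of compound 4 in this assay is 40000 nM, within a range from 12000 nM to 150000 nM. The step from compound 2 to compound 4 is expected to be a step that the limit leaves unreadable from compound 2 to compound 4, which is no change beyond the scatter.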

Compound 4, concentration for 50% growth inhibition: 17400 nM
Estimate against measurement, compound 4: 2.3-fold (0.36 log units) above, within the range that was stated.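

In this assay compound 4 gives 17400 nM, the only actual number among the compounds shown, so a compound of this series can give a measurable value in this assay when trifluoromethoxy stands in place of trifluoromethyl on this aromatic carbon, meta to a large group. The change gives an at least 1.6-fold lower number from compound 2 to compound 4 (0.21 log units; that floor lies within the scatter), so the data cannot yet confirm a real gain. The true size of the step stays unknown because compound 2 has only a limit: the limit of > 28500 nM in this assay, at which 1 of the 4 values shown sits.

Going by these compounds, it remains open whether other groups at this place, such as an amine, a carboxylic acid or a longer chain, would give lower numbers or only further limits. Also open, on these data alone, is whether trifluoromethoxy would give a number at another place on the same ring.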